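The compounds below may be only part of what the source reports. "The series", "measured", "known", "first", "only" and "open" are said of these compounds alone.

Measured so far in a physicochemical assay for acid dissociation:
compound 1 `COc1cccc(CNCCCNc2ccnc3cc(Cc4ccccc4)ccc23)c1O` gives 9.47
compound 2 `Cc1cc(C)cc(Cc2ccc3c(NCCCNCc4ccco4)ccnc3c2)c1` gives 9.47
compound 3 `COc1ccc(F)cc1CNCCCNc1ccnc2cc(-c3ccc(F)cc3)ccc12` gives 9.47

In this assay compound 1 stands level with compound 2 and compound 3 at the digits shown; no gap between any two of these three reaches beyond the usual scatter. Compound 4 `COc1cccc(CNCCCNc2ccnc3cc(Oc4cccc(N(C)C)c4)ccc23)c1O` has not yet been measured. It differs from compound 1 in one place: 3-(dimethylamino)phenoxy in place of benzyl on an aromatic carbon. The change sits on an aromatic carbon of the fused two-ring system, meta to a fused ring and para to a fused ring. Among the measured compounds shown here, no measured pair shows a step to lean on here, so the expected step is one of no change beyond the scatter: no change at the digits printed from compound 1 to compound 4 (within the scatter). Compound 4 is therefore estimated at 9.47, within a range from 9.17 to 9.77.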

Compound 4, acid dissociation constant: 9.28
Beside the measured number, compound 4's estimate is 0.19 log units above it; the range from low to high includes it.
By their numbers in this assay, from the lowest: compounds 4, 1, 2 and 3 (each within the scatter of the next).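

In this assay, 3-(dimethylamino)phenoxy in place of benzyl on an aromatic carbon, meta to a fused ring and para to a fused ring, gives a number 0.19 log units lower from compound 1 to compound 4 (within the scatter), the first step read at this position. The read-out thus stays within the scatter although the entering group brings a nitrogen, an oxygen and hydrogen-bond acceptors that benzyl lacks. No evidence is available to explain this step. Open, going by these compounds, is whether plain phenoxy or a carboxylic acid at this position would also stay within the scatter, and whether the oxygen link or the dimethylamino group accounts for the step.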